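Removing one methoxy from compound 3

The source may hold more compounds than are shown below. What is called first, only, known or untested is meant among the compounds shown, and "the series" means these compounds.

In a functional assay on A549 cells (Homo sapiens) for cytotoxicity, read by sulforhodamine B assay (on this read-out higher numbers stand for weaker inhibition and lower numbers for stronger inhibition), compound 3 `C=C1[C@@H](OC(C)=O)C[C@@H]2[C@](C)(COC=O)[C@H](OC(C)=O)CC[C@@]2(C)[C@@H]1C[C@@H](Nc1ccc(OC)c(OC)c1)C1=CCOC1=O` gives > 50000 nM, which is a limit of the assay and not a number. Among the measured compounds, the position is the limit of > 50000 nM in this assay, at which 1 of the 3 values shown sits. Compound 1 `C=C1[C@@H](OC(C)=O)C[C@@H]2[C@](C)(COC=O)[C@H](OC(C)=O)CC[C@@]2(C)[C@@H]1C[C@@H](Nc1ccc(O)cc1)C1=CCOC1=O` gives 29100 nM, and compound 2 `C=C1[C@@H](OC(C)=O)C[C@@H]2[C@](C)(COC=O)[C@H](OC(C)=O)CC[C@@]2(C)[C@@H]1C[C@@H](Nc1ccc(F)cc1)C1=CCOC1=O` gives 21300 nM. Between these two, the step is a 1.4-fold lower number from compound 1 to compound 2 (0.14 log units; within the scatter).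

Compound 4 `C=C1[C@@H](OC(C)=O)C[C@@H]2[C@](C)(COC=O)[C@H](OC(C)=O)CC[C@@]2(C)[C@@H]1C[C@@H](Nc1ccc(OC)cc1)C1=CCOC1=O` differs from compound 3 as follows: hydrogen in place of methoxy on an aromatic carbon. In words, this is hydrogen in place of methoxy on an aromatic carbon, ortho to a methoxy group and meta to a large group.

Among the compounds with values here, no measured step makes exactly this change. The closest evidence comes from compounds 1 and 2, which also lack the extra methoxy of compound 3. Going into compound 3, the steps are an at least 1.7-fold higher number from compound 1 to compound 3 (0.23 log units; that floor lies within the scatter) and an at least 2.3-fold higher number from compound 2 to compound 3 (0.37 log units; beyond the scatter). Both are floors, so they limit the size of the change only from one side. On that basis, a move to a lower number in this assay is expected, bringing compound 4 near compounds 1 and 2, though it may stay at the limit. The expected step is an at least 1.6-fold lower number from compound 3 to compound 4 (0.22 log units; that floor lies within the scatter). Compound 4 is estimated at 30000 nM, with an expected range of 15000 nM to 50000 nM.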

Compound 4, half-maximal inhibitory concentration: 28900 nM
Compound 4: middle estimate off by 1.0-fold (0.02 log units), on the high side; low and high end bracket the measured number.
By their numbers in this assay, from the lowest: compounds 2, 4 and 1 (each within the scatter of the next). At a limit, above all of these: compound 3.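

In this assay, compound 4 gives a measured number where compound 3 stands at a limit, which shows that the methoxy on the aromatic carbon ortho to a methoxy group can be removed with a readable result, though an at least 1.7-fold lower number from compound 3 to compound 4 (0.23 log units; that floor lies within the scatter) fixes only a floor, so the step itself may be larger than that floor or barely exceed the usual scatter. Compound 3 remains alone at a limit, and that value is a limit and not a number: the limit of > 50000 nM in this assay, at which 1 of the 4 values shown sits. With the 4-methoxyphenyl group now in the series, the other group at the remaining substituted carbon can be read in two further exchanges, a 1.0-fold lower number from compound 1 to compound 4 (0.00 log units; within the scatter) and a 1.4-fold higher number from compound 2 to compound 4 (0.13 log units; within the scatter), so hydroxy, fluoro and methoxy there are not told apart in this assay.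

Open, on these data alone, is the true number of compound 3, and with it the real size of the step from 3,4-dimethoxyphenyl to 4-methoxyphenyl. Also open, as far as these compounds go, is whether a hydroxy, an ethoxy or a chlorine at the carbon ortho to a methoxy group would behave like the hydrogen of compound 4 or like the methoxy of compound 3.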